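The compounds below may be only part of what the source reports. "The series", "measured", "known", "first", "only" and "open" are said of these compounds alone.

Compound 1 `CNC(=O)c1ccc(Oc2cccc(NC(=S)Nc3ccc(Cl)cc3)c2)nc1` is tested in a functional assay on HepG2 cells (Homo sapiens) for antiproliferative activity, read by MTT assay (on this read-out lower numbers stand for stronger inhibition and higher numbers for weaker inhibition), where compound 1 gives 29400 nM. Of the two plain numbers shown, this is the higher one, so compound 1 is the weaker of the pair. Compound 3 `CNC(=O)c1ccc(Oc2cccc(NC(=S)Nc3ccc(Br)c(C(F)(F)F)c3)c2)nc1` gives 8530 nM in this assay, a lower number than compound 1, beyond the usual scatter. Compound 2 `CNC(=O)c1ccc(Oc2cccc(NC(=S)Nc3ccc(C)c(C)c3)c2)nc1` returns only a limit of the assay, > 100000 nM, and not a number. For the measured compounds named here, the single measured step that starts from compound 1 is an at least 3.4-fold higher number from compound 1 to compound 2 (0.53 log units; beyond the scatter), which ends at the limit of > 100000 nM in this assay, at which 1 of the 3 values shown sits.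

The change now considered leads to compound 4 `CNC(=O)c1ccc(Oc2cccc(NC(=S)Nc3ccc(F)c(F)c3)c2)nc1`, and reads: 3,4-difluorophenyl in place of 4-chlorophenyl on an amide-type nitrogen. Going by the values given here, no measured step matches this swap exactly. What the data show is that replacing the 4-chlorophenyl with 3,4-dimethylphenyl in compound 2 pushed the number up to the limit, while compound 3, whose ring carries a bromine and a trifluoromethyl, sits below compound 1. The fluorine-bearing ring of compound 4 lies closer in kind to those of compound 1 and compound 3 than to compound 2. A small rise from compound 1 is therefore expected, a 1.4-fold higher number from compound 1 to compound 4 (0.13 log units; within the scatter), with a real chance that it stays within the scatter. Compound 4 is estimated at 40000 nM, expected between 12000 nM and 130000 nM.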

Compound 4, half-maximal inhibitory concentration: 26700 nM
The estimate for compound 4 lay 1.5-fold (0.18 log units) above the measured number; measured number inside the range.
By their numbers in this assay, from the lowest: compound 3; then compounds 4 and 1 (each within the scatter of the next). At a limit, above all of these: compound 2.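

In this assay, putting 3,4-difluorophenyl in place of 4-chlorophenyl on the amide-type nitrogen gives a 1.1-fold lower number from compound 1 to compound 4 (0.04 log units; within the scatter), so the two cannot be told apart here, even though one ring carries two fluorines and the other a single chlorine. Set against the 3,4-dimethylphenyl ring at the same place, the difluoro ring gives an at least 3.7-fold lower number from compound 2 to compound 4 (0.57 log units; beyond the scatter), which shows that among these two rings, both named as 3,4-substituted, the identity of the groups matters and not just their number. This step gives only a minimum size, since compound 2 is held at a limit of the assay and not at a number: the limit of > 100000 nM in this assay, at which 1 of the 4 values shown sits.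

The ring groups shown here are limited to halogens, trifluoromethyl and methyl, so it remains open how a methoxy group, a nitrile or a dimethylamino group would behave at this place. Also open, from the compounds shown here alone, is whether one fluorine alone, as in a 4-fluorophenyl ring, would sit with compound 1 and compound 4, and which single group on the ring of compound 3 accounts for its lower number.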